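Cytotoxicity notes: chloro for trifluoromethyl on the sulfonamide aryl

A few compounds are considered here, and "the series" means these few. Any claim that something is new, unique, unknown or untested is made for them only; others in the source may bear on it.

The series shares one core and is followed in an ADME assay on HEK293 cells (Homo sapiens) for cytotoxicity, read by resazurin assay, with a stated time of 48 h; a lower number here means that less compound is tolerated, a higher number that more compound is tolerated. Compound 1 `O=S(=O)(Nc1ccc(-c2nc3ccccc3o2)cc1)c1ccccc1C(F)(F)F` carries a trifluoromethyl on the sulfonamide-bearing ring. For compound 1 the result is a limit of the assay, > 100000 nM, so only a floor and no number is known; this is the case described by the limit of > 100000 nM in this assay, at which 1 of the 3 values shown sits. Compound 2 `Cc1cccc(S(=O)(=O)Nc2ccc3oc(-c4ccccc4)nc3c2)c1` gives 69000 nM in this assay, and compound 3 `O=S(=O)(Nc1ccc(-c2nc3ccccc3o2)cc1)c1ccc(Cl)c(C(F)(F)F)c1` gives 69000 nM, the two values lying within the scatter of each other.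

Compound 4 `O=S(=O)(Nc1ccc(-c2nc3ccccc3o2)cc1)c1ccccc1Cl` is the unmeasured analogue of compound 1. It differs by chloro in place of trifluoromethyl on an aromatic carbon. For the measured compounds named here, no measured pair in the set spans this change, so its effect is unknown. All three measured values sit at the high end of the range, and the change is expected to move the number by an at least 1.1-fold lower number from compound 1 to compound 4 (0.07 log units; that floor lies within the scatter), that is, by no more than the usual scatter. Compound 4 is therefore estimated at 85000 nM in this assay, within the range 40000 nM to 150000 nM, with a fair chance that only a limit is reported.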

Compound 4, half-maximal cytotoxic concentration: > 100000 nM
Compound 4: only a limit was reported (the forecaster's own chance of this, stated with the estimate: 50%); at least 1.1-fold (0.07 log units) between middle value and limit.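

Compound 1 and compound 4 both stand only as limits of the assay, so no step can be read for chloro in place of trifluoromethyl: the limit of > 100000 nM in this assay, at which 2 of the 4 values shown sit. The compounds shown leave open whether this change shifts the tolerated concentration at all, and in which direction.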